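Where Compound 1 Stands and What Compound 4 May Give

A few compounds are considered here, and "the series" means these few. Any claim that something is new, unique, unknown or untested is made for them only; others in the source may bear on it.

Compound 1 `Cc1ccc(S/C(=C/c2c(O)cc(O)cc2O)C(=O)c2ccc(Cl)cc2)cc1` — > 100000 nM
Compound 2 `O=C(/C(=C\c1c(O)cc(O)cc1O)Sc1ccccc1Br)c1ccc(Cl)cc1` — > 100000 nM
Compound 3 `O=C(/C(=C\c1c(O)cc(O)cc1O)S(=O)(=O)c1ccc(Br)cc1)c1ccc(Cl)cc1` — > 100000 nM

In a functional assay on DU-145 cells (Homo sapiens) for inhibition, read by trypan blue exclusion, with a stated time of 96 h (on this read-out lower numbers stand for stronger inhibition of growth and higher numbers for weaker inhibition of growth), compound 1 gives > 100000 nM, which is a limit of the assay and not a number. Compound 2 likewise reaches only a limit, > 100000 nM. For compound 3 the result is also a limit, > 100000 nM. All three values sit at the limit of > 100000 nM in this assay, at which 3 of the 3 values shown sit, so the three steps among them are unreadable: a step that the two limits leave unreadable from compound 1 to compound 2, a step that the two limits leave unreadable from compound 1 to compound 3 and a step that the two limits leave unreadable from compound 2 to compound 3.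

Compound 4 `Cc1ccc(S/C(=C/c2ccc(Cl)cc2)C(=O)c2ccc(Cl)cc2)cc1` is not yet measured. It differs from compound 1 in one place: 4-chlorophenyl in place of 2,4,6-trihydroxyphenyl on a double-bonded chain carbon bound to a double-bonded chain carbon. Among the measured compounds shown here, none of the measured steps touches this part of the shared core; they all change the group on the sulfur, and none gives a readable size. For the measured compounds named here, there is therefore no measured step that bears on the change from compound 1 to compound 4, and no direction can be read from the data.

Given that compound 1 sits only at a limit, compound 4 is expected to give about 100000 nM, within a range from 30000 nM to 300000 nM, most probably again as a limit. The step that this estimate means, a number no higher from compound 1 to compound 4 (the limit leaves the size open), is expected to be none beyond the scatter.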

Compound 4, concentration for 50% growth inhibition: 10000 nM
Beside the measured number, compound 4's estimate is 10-fold (1.00 log units) above it; the whole stated range lies above it.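

In this assay, the double-bonded chain carbon bound to a double-bonded chain carbon proves to be a place where a change gives a readable result: 4-chlorophenyl in place of 2,4,6-trihydroxyphenyl produces an at least 10-fold lower number from compound 1 to compound 4 (1.00 log units; beyond the scatter). Among the compounds shown here, the steps among compound 1, compound 2 and compound 3, which all change the group on the sulfur, cannot be read, so compound 4 is the only one of the four compounds with a value that is a number. The true size of the step remains open because compound 1 gives only a limit, and the printed size is therefore a lower bound: the limit of > 100000 nM in this assay, at which 3 of the 4 values shown sit.

The change swaps a group with 3 hydrogen-bond donors and 3 hydrogen-bond acceptors for one with none and also brings in a chlorine, so the compounds shown do not separate the loss of the hydroxyl groups from the gain of the chlorine; an unsubstituted phenyl or a 4-hydroxyphenyl at this place would bear on that question. As far as these compounds go, it also remains open whether the group on the sulfur matters once 4-chlorophenyl is present, as a (4-bromophenyl)sulfonyl group in place of the (4-methylphenyl)sulfanyl group of compound 4 would show.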